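The compounds below may be only part of what the source reports. "The series", "measured", "known", "first", "only" and "open" are said of these compounds alone.

Measured compounds:
compound 1, `Cc1noc(C)c1-c1ccc2c(c1)C(c1ccccc1)N(Cc1nnc(-c3ccccc3)o1)C(=O)N2C`: 26.7%
compound 2, `Cc1noc(C)c1-c1ccc2c(c1)C(c1ccccc1)N(Cc1ncc(-c3ccccc3)o1)C(=O)N2C`: 15.1%

In a functional assay on U-266 cells (Homo sapiens) for inhibition, read by MTT assay, with a stated time of 48 h, tested at 0.1 uM (on this read-out lower numbers stand for less inhibition and higher numbers for more inhibition at the one concentration tested (going by the name of the read-out)), compound 1 gives 26.7%, and compound 2 gives 15.1%. Compound 1 thus stands highest of the two numbers shown, with compound 2 as its nearest neighbour, the step being a number 11.6 percentage points lower from compound 1 to compound 2 (beyond the scatter). The unmeasured compound 3, `Cc1noc(C)c1-c1ccc2c(c1)C(c1ccccc1)N(Cc1nnc(-c3ccccc3)s1)C(=O)N2C`, differs from compound 1 in one place: 5-phenyl-1,3,4-thiadiazol-2-yl in place of 5-phenyl-1,3,4-oxadiazol-2-yl on a saturated chain carbon bound to an amide-type nitrogen in a ring. Among the measured compounds shown here, only one measured step exists, and it alters the same group at the same place, but to a different ring, so it bears on the new step only loosely; it shows that reworking this group can move this assay by a modest amount. With no closer comparison available, the expected step is a number 4.7 percentage points lower from compound 1 to compound 3 (within the scatter), a shift that may well stay within the scatter. Compound 3 is therefore estimated at 22%, with a range from 8% to 40%.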

Compound 3, a percentage reported as inhibition, at one concentration (the size of the read-out at that concentration, not a potency): 20.3%
Beside the measured number, compound 3's estimate is 1.7 percentage points above it; low and high end bracket the measured number.
By their numbers in this assay, from the lowest: compounds 2, 3 and 1 (each within the scatter of the next, the first and the last beyond it).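

In this assay, putting 5-phenyl-1,3,4-thiadiazol-2-yl in place of 5-phenyl-1,3,4-oxadiazol-2-yl gives a number 6.4 percentage points lower from compound 1 to compound 3 (within the scatter) and so cannot be told apart from no change, even though sulfur has replaced oxygen in the five-membered ring. Measured against the 5-phenyl-1,3-oxazol-2-yl group, the same thiadiazole gives a number 5.2 percentage points higher from compound 2 to compound 3 (within the scatter) and thus lies within reach of both other compounds, leaving the gap between compound 1 and compound 2 as the only one beyond the scatter. Nothing available here explains how these three rings compare.

On these data alone, all three compounds carry a phenyl-bearing five-membered aromatic ring at this place, so the effect of a simple amine, a carboxylic acid or a longer chain there remains open. Also open, as far as these compounds go, is what a methoxy group or a chlorine on the phenyl ring would do.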